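This account rests on a few compounds, and the source may have more. Where it says the series, first, only, none or still open, it means among the compounds named here.

Going by the values given here, compound 2, `O=C(NCc1ccc(CNS(=O)(=O)c2cccc(F)c2)cc1)c1ccc(F)cc1`, sits at the less favourable end of the two numbers so far. In an assay on MDA-MB-231 cells for binding affinity to C-X-C chemokine receptor type 4 (Homo sapiens), read by fluorescence and microscopy, with stated times of 10 min and 30 min (on this read-out higher numbers stand for an effect only at larger amounts of compound and lower numbers for an effect already at smaller amounts), compound 2 gives 1000 nM, whereas compound 1, `O=C(NCc1ccc(CNS(=O)(=O)c2ccc(Cl)cc2)cc1)c1ccc(F)cc1`, gives 100 nM. Among the compounds with values here, the one measured step, a 10-fold higher number from compound 1 to compound 2 (1.00 log units; beyond the scatter), is the only comparison in hand, and it concerns the same position that is now varied.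

Compound 3 is `O=C(NCc1ccc(CNS(=O)(=O)c2cccc3ccccc23)cc1)c1ccc(F)cc1`. Within the data shown here, the change naphthalen-1-yl in place of 3-fluorophenyl on a sulfonyl sulfur again alters the group on the sulfonyl sulfur, so the single earlier step bears on it as far as it can: swapping one aryl for another at this sulfur moved this assay by a full order, which is beyond the scatter and shows that this position is responsive. Nothing measured tells which way naphthalen-1-yl will go, but since compound 1 with 4-chlorophenyl gives a lower number than compound 2, the expectation is that a further aryl replacement is more likely to step down than up, though not back to the level of compound 1. Compound 3 is therefore expected to give 300 nM in this assay, within 60 nM to 1500 nM, an expected step of a 3.3-fold lower number from compound 2 to compound 3 (0.52 log units; beyond the scatter).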

Compound 3, effective concentration (reported as EC, without a stated level of effect): 1000 nM
Compound 3: middle estimate off by 3.3-fold (0.52 log units), on the low side, within the range that was stated.
By their numbers in this assay, from the lowest: compound 1; then compounds 2 and 3 (each within the scatter of the next).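

In this assay, putting naphthalen-1-yl in place of 3-fluorophenyl on a sulfonyl sulfur gives no change at the digits printed from compound 2 to compound 3 (within the scatter), so this position, though it responded to the earlier exchange, does not respond to every exchange of one aryl group for another. Going from one six-membered aromatic ring of carbon only to two, and losing the fluorine, leaves the printed number as it was, while the comparison with 4-chlorophenyl gives a 10-fold higher number from compound 1 to compound 3 (1.00 log units; beyond the scatter), the same size as the earlier step, so that of the three groups on this sulfur only 4-chlorophenyl stands apart. Nothing measured here accounts for either result.

On these data alone, it remains open whether the lower number of compound 1 goes with the chlorine itself or with the 4-chlorophenyl group as a whole, which a group such as 4-bromophenyl, 4-methoxyphenyl or 3-chlorophenyl on the same sulfur would help to separate. As far as these compounds go, it is also open how this assay would read with a group on the sulfonyl sulfur that is not a carbon-only aryl ring, such as pyridin-3-yl or a plain methyl.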